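Sulfonyl aryl swap: human liver microsome clearance notes

The source may hold more compounds than are shown below. What is called first, only, known or untested is meant among the compounds shown, and "the series" means these compounds.

Measured so far:
compound 1 `Cc1ccc(S(=O)(=O)c2cnc3cc(F)ccc3c2-c2ccc(F)cc2)cc1C`, 9.25 mL/min
compound 2 `COc1ccc(-c2c(S(=O)(=O)c3cccc(F)c3)cnc3cc(F)ccc23)cc1`, 1.89 mL/min
compound 3 `O=S(=O)(c1cc(Cl)cc(Cl)c1)c1cnc2cc(F)ccc2c1-c1ccc(F)cc1`, 0.18 mL/min

In an ADME assay on microsomes from liver (Homo sapiens) for metabolic stability, tested at 2.5 uM (a lower number here means slower removal, a higher number faster removal of the compound), compound 3 gives the lowest number of the three; compound 2 lies nearer to it, compound 1 furthest. Within the data shown here, the one step at the sulfonyl sulfur is a 51-fold lower number from compound 1 to compound 3 (1.71 log units; beyond the scatter), so the group on that sulfur moves the number strongly.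

Compound 4 `O=S(=O)(c1cccc(F)c1)c1cnc2cc(F)ccc2c1-c1ccc(F)cc1` is the next variation: 3-fluorophenyl in place of 3,5-dichlorophenyl on a sulfonyl sulfur. Among the measured compounds shown here, no step measures this exact exchange, but compound 2, which also carries 3-fluorophenyl on the sulfonyl sulfur, gives 1.89 mL/min in this assay. A higher number than compound 3 is therefore expected, an 8.3-fold higher number from compound 3 to compound 4 (0.92 log units; beyond the scatter). Compound 4 is estimated at 1.5 mL/min, with a range from 0.5 mL/min to 5 mL/min.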

Compound 4, intrinsic clearance in a liver preparation (reported as CLH), per the amount of preparation that the assay uses: 0.11 mL/min
Compound 4: the middle estimate sits 14-fold (1.13 log units) above what was measured; the whole stated range lies above it.
By their numbers in this assay, from the lowest: compounds 4 and 3 (each within the scatter of the next); then compound 2; then compound 1.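

In this assay, 3-fluorophenyl and 3,5-dichlorophenyl on a sulfonyl sulfur cannot be told apart (a 1.6-fold lower number from compound 3 to compound 4 (0.21 log units; within the scatter)), whereas 3-fluorophenyl in place of 3,4-dimethylphenyl gives a large drop (an 84-fold lower number from compound 1 to compound 4 (1.92 log units; beyond the scatter)). The strong effect at the sulfur therefore holds for 3,4-dimethylphenyl against either halogenated ring. A second place also matters: fluoro in place of methoxy on an aromatic carbon gives a large drop as well (a 17-fold lower number from compound 2 to compound 4 (1.24 log units; beyond the scatter)).

From the compounds shown here alone, whether an amine or a carboxylic acid in place of the aryl group on the sulfonyl sulfur would keep the number this low stays open. No evidence at hand explains these differences.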